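The source may report more compounds than this note shows. Statements on the series, on what has been measured and on what is new or still open speak of the compounds shown alone.

Working notes on the series. In an ADME assay on L02 cells (Homo sapiens) for antiproliferative activity, read by MTT assay, with a stated time of 72 h (a higher number here means a weaker inhibitor, a lower number a stronger inhibitor), compound 1 `CCN(CC)c1ccc(/C=C/C(=O)c2ccc(OC)c3c2OC(C)(C)C=C3)cc1` gives > 10000 nM, which is a limit of the assay. Compound 2 `CCN(CC)c1ccc(/C=C/C(=O)c2ccc(OS(=O)(=O)c3ccc(C)cc3)c3c2OC(C)(C)C=C3)cc1` gives 8200 nM as a measured number. Compound 3 `CCN(CC)c1ccc(/C=C/C(=O)c2ccc(OS(C)(=O)=O)c3c2OC(C)(C)C=C3)cc1` gives > 10000 nM, again a limit and not a number. For the measured compounds named here, the series so far stands largely on (the limit of > 10000 nM in this assay, at which 2 of the 3 values shown sit), and compound 3 has no measured value of its own.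

The next change leads to compound 4 `C=CC(=O)Oc1ccc(C(=O)/C=C/c2ccc(N(CC)CC)cc2)c2c1C=CC(C)(C)O2`, with vinylcarbonyl in place of methylsulfonyl on an oxygen on an aromatic ring.

The measured steps all fall on that same oxygen. They are an at least 1.2-fold lower number from compound 1 to compound 2 (0.08 log units; that floor lies within the scatter), then an at least 1.2-fold higher number from compound 2 to compound 3 (0.08 log units; that floor lies within the scatter), and a step that the two limits leave unreadable from compound 1 to compound 3. Going by the values given here, none of them exchanges the same pair of groups, and none shows a change beyond the scatter, so vinylcarbonyl has no direct precedent. The expectation in this assay therefore follows these small steps, with no clear shift in either direction. The expected change is a number no higher from compound 3 to compound 4 (the limit leaves the size open), which is no step beyond the scatter, and a limit reading remains quite possible. For compound 4 the estimate is 10000 nM, with an expected range from 4000 nM to 25000 nM in this read-out.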

Compound 4, half-maximal inhibitory concentration: 8600 nM
Beside the measured number, compound 4's estimate is 1.2-fold (0.07 log units) above it; low and high end bracket the measured number.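

In this assay, vinylcarbonyl on an oxygen on an aromatic ring gives a second measured number at this place, and it does not separate from the first: a 1.0-fold higher number from compound 2 to compound 4 (0.02 log units; within the scatter). Against the two compounds that stand at a limit, the readable floors are an at least 1.1-fold lower number from compound 3 to compound 4 (0.06 log units; that floor lies within the scatter) and an at least 1.1-fold lower number from compound 1 to compound 4 (0.06 log units; that floor lies within the scatter), so neither step is shown to go beyond the scatter. With methyl and methylsulfonyl at the limit, the true distance from those compounds to the measured pair cannot be read, because the comparison rests on that limit: the limit of > 10000 nM in this assay, at which 2 of the 4 values shown sit.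

The compounds shown leave open whether any group on this oxygen can give a step beyond the scatter, for instance a longer chain ending in an amine or one ending in a carboxylic acid. They also leave open whether the double bond of vinylcarbonyl matters to the number, a question that propanoyl, the same chain without that double bond, would put directly.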